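The compounds below may be only part of what the source reports. "The series", "measured", "known", "first", "only" and "open" are said of these compounds alone.

Compound 1 `COC(=O)c1cc(-c2cccc(NC(=O)c3ccc(/C=C/C(=O)c4cccc(OC)c4)cc3)c2)on1` is the starting point of this account. In an ADME assay on Vero cells (Chlorocebus sabaeus) for cytotoxicity, read by MTT assay, with a stated time of 72 h (on this read-out lower numbers stand for higher toxicity in this test and higher numbers for lower toxicity in this test), compound 1 gives a limit of the assay rather than a number, > 100 ug/mL. Compound 2 `COC(=O)c1cc(-c2cccc(NC(=O)c3ccc(/C=C/C(=O)c4ccc(F)cc4)cc3)c2)on1` likewise gives only a limit, > 20 ug/mL. The step that the two limits leave unreadable from compound 1 to compound 2 therefore cannot be read, because both values sit at limits (the limit of > 100 ug/mL in this assay, at which 1 of the 2 values shown sits, (the limit of > 20 ug/mL in this assay, at which 1 of the 2 values shown sits)). Compound 3 `COC(=O)c1cc(-c2cccc(NC(=O)c3ccc(/C=C/C(=O)c4ccccc4Br)cc3)c2)on1` carries the change (2-bromophenyl in place of 3-methoxyphenyl on a carbonyl carbon). For the measured compounds named here, no measured step tells how such a change acts, and compound 1 is known only as a limit, so compound 3 is expected to stay near that limit, the estimated step being a number no higher from compound 1 to compound 3 (the limit leaves the size open). The estimate for compound 3 is 100 ug/mL, between 40 ug/mL and 200 ug/mL.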

Compound 3, half-maximal cytotoxic concentration: > 40 ug/mL
Compound 3: only a limit was reported; the forecaster's own chance of this, stated with the estimate: 70%; the middle value is on the limit's open side.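

For the compounds shown here, compound 1, compound 2 and compound 3 all give only limits in this assay, and no step among them can be read. The compounds shown leave open whether 3-methoxyphenyl, 4-fluorophenyl or 2-bromophenyl on a carbonyl carbon changes the half-maximal cytotoxic concentration at all.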